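The compounds below may be only part of what the source reports. "The series", "measured", "known", "first", "only" and "open" are said of these compounds alone.

Measured so far:
- compound 1, `OC(CCn1nc2c(Br)c(Br)c(Br)c(Br)c2n1)c1cccc(Br)c1`: 0%
- compound 2, `COc1cccc(C(O)CCn2nc3c(Br)c(Br)c(Br)c(Br)c3n2)c1`: 2%
- compound 3, `C[C@@H](O)CCn1nc2c(Br)c(Br)c(Br)c(Br)c2n1`: 24%

All three share one core and were tested in a functional assay on CCRF-CEM cells (Homo sapiens) for antiproliferative activity, read by MTT assay, with a stated time of 48 h, tested at 100 uM; a lower number here means a stronger effect, a higher number a weaker effect of the compound at the concentration tested. Compound 2 gives 2%, the second highest of the three numbers, with compound 1 closest, its value 0% lying within the scatter of that of compound 2. Compound 3, with its value 24%, sits clearly higher than compound 2.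

The next compound, compound 4, `OC(CCn1nc2c(Br)c(Br)c(Br)c(Br)c2n1)c1ccccc1`, differs from compound 2 by hydrogen in place of methoxy on an aromatic carbon. Within the data shown here, only one measured step bears on this: a number 2 percentage points higher from compound 1 to compound 2 (within the scatter), which swapped one group on the same aromatic ring for another and left the read-out unchanged within the scatter. Taking away the group at that position is therefore expected to give a step of a number 3 percentage points higher from compound 2 to compound 4 (within the scatter) in this assay, that is, none beyond the scatter. Compound 4 is accordingly estimated at 5%, with a range from 0% to 20%.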

Compound 4, a percentage reported as activity, at one concentration (the size of the read-out at that concentration, not a potency): 0%
The estimate for compound 4 lay 5 percentage points above the measured number, and the stated range covers the measured number.
By their numbers in this assay, from the lowest: compounds 1, 4 and 2 (each within the scatter of the next); then compound 3.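

In this assay taking the methoxy away gives a number 2 percentage points lower from compound 2 to compound 4 (within the scatter) and putting hydrogen in place of bromo gives no change at the digits printed from compound 1 to compound 4 (within the scatter) so the bare phenyl now joins the comparison. Earlier, only one substituent had been swapped for another; now the ring without any substituent at this place also stays within the scatter of both substituted compounds, so bromo, methoxy and hydrogen cannot be told apart here. Nothing on hand explains this lack of separation.

On these data alone, whether an amine or a carboxylic acid at this same place would shift the number beyond the scatter remains open. As far as these compounds go, compound 1, compound 2 and compound 4 are also compared at one concentration only, so any differences in potency among them also remain open.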